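Opening a Ring: Cyclohexyl to Isopropyl on the Side Chain

This account rests on a few compounds, and the source may have more. Where it says the series, first, only, none or still open, it means among the compounds named here.

Compound 1, `O=C(O)c1ccccc1-c1ccc(CCc2ncc(CC3CCC3)[nH]2)cc1`: 7.1 nM
Compound 2, `O=C(O)c1ccccc1-c1ccc(CCc2ncc(CCC3CCCCC3)[nH]2)cc1`: 33 nM

In an in vitro functional assay on cells for agonist activity at Bombesin receptor subtype-3 (Mus musculus), read by luminescence and calcium flux (on this read-out lower numbers stand for an effect already at smaller amounts and higher numbers for an effect only at larger amounts of compound), compound 2 gives the higher of the two numbers. For the measured compounds named here, the one measured step is a 4.6-fold higher number from compound 1 to compound 2 (0.67 log units; beyond the scatter), where cyclohexylmethyl replaced cyclobutyl and the number rose. Compound 3, `CC(C)CCc1cnc(CCc2ccc(-c3ccccc3C(=O)O)cc2)[nH]1`, is not yet measured; it differs from compound 2 by isopropyl in place of cyclohexyl on a saturated chain carbon, two bonds along the chain from an aromatic carbon. Going by the values given here, since the only comparison available shows the larger ring-bearing chain with the higher number, losing the ring may pull the number down, though a step within the scatter is equally plausible. For compound 3 the estimate is 18 nM, ranging from 6 nM to 55 nM. This is expected to mean a 1.8-fold lower number from compound 2 to compound 3 (0.26 log units; within the scatter).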

Compound 3, half-maximal effective concentration: 10 nM
Beside the measured number, compound 3's estimate is 1.8-fold (0.26 log units) above it; the measured number falls inside the stated range.
By their numbers in this assay, from the lowest: compounds 1 and 3 (each within the scatter of the next); then compound 2.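

Going from cyclohexyl to isopropyl brings a 3.3-fold lower number from compound 2 to compound 3 (0.52 log units; beyond the scatter) in this assay and shows that a ring at this place on the chain is not needed for a low number. The open isobutyl chain of compound 3 also matches the cyclobutyl chain of compound 1, with a 1.4-fold higher number from compound 1 to compound 3 (0.15 log units; within the scatter) between them. No evidence on hand explains these shifts. Still open, as far as these compounds go, is whether an amine or a hydroxyl group in place of isopropyl would keep the number this low.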